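The source may report more compounds than this note shows. Statements on the series, on what has been measured and on what is new or still open speak of the compounds shown alone.

Three compounds built on a shared core were tested in an assay on CHO-K1 cells for inhibition of 11-beta-hydroxysteroid dehydrogenase type 2 (Homo sapiens), read by scintillation proximity assay; on this read-out lower numbers stand for stronger inhibition and higher numbers for weaker inhibition. Compound 1 `CCOCC12CCC(c3nnc(-c4ccccc4C(F)(F)F)n3C)(CC1)CC2` carries an ethoxy group on a saturated chain carbon bound to a saturated ring carbon. In this assay compound 1 gives > 4000 nM, which is a limit of the assay and not a number. Compound 2 `Cn1c(-c2ccccc2C(F)(F)F)nnc1C12CCC(CCS(C)(=O)=O)(CC1)CC2` has (methylsulfonyl)methyl in that position. In this assay compound 2 gives > 4000 nM, again a limit of the assay. Compound 3 `Cn1c(-c2ccccc2C(F)(F)F)nnc1C12CCC(CNS(C)(=O)=O)(CC1)CC2` carries methanesulfonamido there. In this assay compound 3 gives > 4000 nM, also a limit of the assay. Compound 3 thus stands at the same limit as the other two, and nothing more can be said of its position, because of the limit of > 4000 nM in this assay, at which 3 of the 3 values shown sit. The three steps among them, a step that the two limits leave unreadable from compound 1 to compound 2, a step that the two limits leave unreadable from compound 1 to compound 3 and a step that the two limits leave unreadable from compound 2 to compound 3, remain unreadable in size for the same reason.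

Compound 4 `Cn1c(-c2ccccc2C(F)(F)F)nnc1C12CCC(CCS(=O)(=O)C(C)(C)C)(CC1)CC2` differs from compound 3 by ((tert-butyl)sulfonyl)methyl in place of methanesulfonamido on a saturated chain carbon bound to a saturated ring carbon. The three measured steps bear on this change only in that each exchange at this position left the value at the limit; none gives a readable size. Compound 4 is therefore expected to show a step that the limit leaves unreadable from compound 3 to compound 4 in this assay, most likely reported again only as a limit. Compound 4 is estimated at 6000 nM, within 1500 nM to 30000 nM.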

Compound 4, half-maximal inhibitory concentration: > 4000 nM
Compound 4: no number, only a limit (the forecaster's own chance of this, stated with the estimate: 75%); the middle value is on the limit's open side.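

Within the data shown here, compound 4, like compound 1, compound 2 and compound 3, gives only a limit of the assay and not a number, so no step among them can be read in this assay: the limit of > 4000 nM in this assay, at which 4 of the 4 values shown sit. The compounds shown leave open how strongly any of the four inhibits, and whether any exchange of these groups changes inhibition at all.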